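Chalcone-imidazolone series: methoxy to chloro on the pendant phenyl

This account rests on a few compounds, and the source may have more. Where it says the series, first, only, none or still open, it means among the compounds named here.

Measured so far:
compound 1 `COc1cc(/C=C/C(=O)c2cccc(-n3cc(-c4ccccc4)[nH]c3=O)c2)ccc1O` gives 2110 nM
compound 2 `O=C(/C=C/c1cccc(O)c1)c1cccc(-n2cc(-c3ccc(Cl)cc3)[nH]c2=O)c1` gives 580 nM
compound 3 `COc1ccc(-c2cn(-c3cccc(C(=O)/C=C/c4ccc(O)c(OC)c4)c3)c(=O)[nH]2)cc1` gives 3450 nM

In a functional assay on U-251 cells (Homo sapiens) for inhibition (on this read-out higher numbers stand for weaker inhibition of growth and lower numbers for stronger inhibition of growth), compound 3 carries the highest number of the three. Its nearest neighbour is compound 1, and the step of a 1.6-fold higher number from compound 1 to compound 3 (0.21 log units; within the scatter) lies within the scatter, so the two are not separated. Compound 2 sits well apart: its value and that of compound 3 differ beyond the scatter, compound 2 having the lower number.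

Compound 4 `COc1cc(/C=C/C(=O)c2cccc(-n3cc(-c4ccc(Cl)cc4)[nH]c3=O)c2)ccc1O` differs from compound 3 by chloro in place of methoxy on an aromatic carbon. Going by the values given here, no measured step covers this exact exchange. Among the compounds with values here, the only single-point step available, from compound 1 to compound 3, concerns methoxy against hydrogen at the same position and is within the scatter. Compound 2 carries the chloro group on that ring but also differs from compound 3 elsewhere, so its low number cannot be assigned to the chloro alone. On this basis the step of a 2.5-fold lower number from compound 3 to compound 4 (0.39 log units; beyond the scatter) is expected to be modest and toward a lower number, with wide uncertainty. Compound 4 is therefore estimated at 1400 nM, within 500 nM to 3500 nM.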

Compound 4, concentration for 50% growth inhibition: 2230 nM
The estimate for compound 4 lay 1.6-fold (0.20 log units) below the measured number, and the stated range covers the measured number.
By their numbers in this assay, from the lowest: compound 2; then compounds 1, 4 and 3 (each within the scatter of the next).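

In this assay, the exchange of 4-methoxyphenyl for 4-chlorophenyl gives a 1.5-fold lower number from compound 3 to compound 4 (0.19 log units; within the scatter) and chloro in place of hydrogen gives a 1.1-fold higher number from compound 1 to compound 4 (0.02 log units; within the scatter), so hydrogen, methoxy and chloro on this aromatic carbon are not separated in these compounds. With chloro held constant, 4-hydroxy-3-methoxyphenyl in place of 3-hydroxyphenyl gives a 3.8-fold higher number from compound 2 to compound 4 (0.58 log units; beyond the scatter), which ties the low number of compound 2 to that exchange and not to the chloro. No supporting data bear on why these steps take the sizes they do.

On these data alone, whether the 3-hydroxyphenyl exchange has the same effect with hydrogen or methoxy in place of chloro remains open. Also open is whether an amine or a carboxylic acid on this aromatic carbon would separate from the three groups shown.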